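Swapping One Aryl Group at the Shared Core

The compounds below may be only part of what the source reports. "The series", "measured", "known", "first", "only" and "open" are said of these compounds alone.

Of the compounds shown here, three with a shared core have been tested in a functional assay on the whole organism (strain Wistar) for inhibition, with Rattus norvegicus as the target, read by paw edema, with stated times of 30 min and 3 h, at a dose of 200 mg/kg by the oral route; on this read-out higher numbers stand for more inhibition at the one dose given (going by the name of the read-out) and lower numbers for less inhibition. Compound 1 `CC(=O)Oc1ccc(-n2c(-c3ccccc3)cc3c2CCCC3)cc1C(=O)O` gives 50%. Compound 2 `COc1ccc(-n2c(-c3ccccc3)cc3c2CCCC3)cc1C(=O)O` gives 40%; the step of a number 10 percentage points lower from compound 1 to compound 2 (within the scatter) stays within the scatter. Compound 3 `COc1ccccc1-c1cc2c(n1-c1ccc(O)c(C(=O)O)c1)CCCC2` gives 50%, level with compound 1 as measured, and together with compound 1 it holds the highest of the three numbers; its gap to compound 2 is also within the scatter.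

Compound 4 `O=C(O)c1cc(-n2c(-c3ccc(O)cc3)cc3c2CCCC3)ccc1O` has not been measured. It differs from compound 3 in one place: 4-hydroxyphenyl in place of 2-methoxyphenyl on an aromatic carbon. For the measured compounds named here, no measured step touches this position. Going by the values given here, the only measured step, a number 10 percentage points lower from compound 1 to compound 2 (within the scatter), concerns a different part of the molecule and was itself within the scatter, so it gives no guide to the present change. With nothing showing that this position moves the read-out, the nearest reference is the value of compound 3, and the expected step is a number 2 percentage points lower from compound 3 to compound 4 (within the scatter), within the scatter. The estimate for compound 4 in this assay is 48%, with a range from 30% to 65%.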

Compound 4, a percentage reported as inhibition, in the whole organism at one dose (the size of the read-out at that dose, not a potency): 20%
Compound 4: the middle estimate sits 28 percentage points above what was measured; the measured number lies below the stated range.
By their numbers in this assay, from the lowest: compound 4; then compounds 2, 1 and 3 (each within the scatter of the next).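

In this assay, with 4-hydroxyphenyl in place of 2-methoxyphenyl on the aromatic carbon next to the ring nitrogen, the result is a number 30 percentage points lower from compound 3 to compound 4 (beyond the scatter). For the compounds shown here, the only earlier step stayed within the scatter, so this is the first sign in the set that a change to the shared core's substituents can move the read-out, and it shows that this position is sensitive to the aryl group it carries. Nothing measured here accounts for the step.

This change alters both the group on the phenyl ring and where it sits on that ring, and the compounds shown cannot separate the two. Going by these compounds, how an aminophenyl group or a longer alkyl chain would behave at this position also remains open.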